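The source may report more compounds than this note shows. Statements on the series, on what has been measured and on what is new or still open speak of the compounds shown alone.

Measured in a functional assay on M14 cells (Homo sapiens) for cytotoxicity, read by MTT assay, with a stated time of 72 h; a lower number here means a stronger inhibitor, a higher number a weaker inhibitor:
compound 1 `CC(=O)n1cc(/C=C(/C(=O)O)c2ccc(OCc3ccccc3)cc2)c2cc(OCc3ccccc3)ccc21` gives 58200 nM
compound 2 `COc1ccc(Cn2cc(/C=C(/C(=O)O)c3ccccc3)c3cc(OCc4ccccc4)ccc32)cc1` gives 64500 nM
compound 3 `COc1ccccc1/C(=C\c1cn(C(C)=O)c2ccc(OCc3ccccc3)cc12)C(=O)O` gives > 100000 nM

Compound 1 and compound 2 return numbers that lie within the usual scatter of each other, so no order between them is claimed. Compound 3 stands apart: its entry is a limit of this assay and not a number, as recorded in the limit of > 100000 nM in this assay, at which 1 of the 3 values shown sits. Where compound 3 actually sits beyond that limit is unknown.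

Compound 4 `COc1ccc(/C(=C\c2cn(C(C)=O)c3ccc(OCc4ccccc4)cc23)C(=O)O)cc1` has not yet been run in this assay. It differs from compound 3 by 4-methoxyphenyl in place of 2-methoxyphenyl on a double-bonded chain carbon bound to a carbonyl carbon and a double-bonded chain carbon. Among the measured compounds shown here, no measured pair of compounds isolates this particular change, so the size of the step rests on expectation alone. Compound 1 and compound 2 both carry a substituted or plain phenyl on this chain carbon and return numbers, whereas compound 3 does not; the expectation is that compound 4 behaves more like the former two. The step from compound 3 to compound 4 is therefore expected to run toward stronger inhibition, an at least 1.4-fold lower number from compound 3 to compound 4 (0.15 log units; that floor lies within the scatter), though with compound 3 at a limit its size cannot be fixed. Compound 4 is expected to give about 70000 nM, within 30000 nM to 160000 nM, with a real chance that only a limit is again reported.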

Compound 4, half-maximal inhibitory concentration: > 100000 nM
Compound 4: no number, only a limit; the forecaster's own chance of this, stated with the estimate: 35%; middle value at least 1.4-fold (0.15 log units) away from the limit.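

In this assay compound 4 gives > 100000 nM, which is a limit of the assay and not a number, so 4-methoxyphenyl in place of 2-methoxyphenyl on this chain carbon does not return a measurable value, and the step from compound 3 cannot be read. Hydrogen in place of phenyl on a saturated chain carbon bound to an oxygen on an aromatic ring gives an at least 1.7-fold higher number from compound 1 to compound 4 (0.23 log units; that floor lies within the scatter), so this pair does not establish a real loss. The limit now holds more than one entry: the limit of > 100000 nM in this assay, at which 2 of the 4 values shown sit.

Going by these compounds, how far compound 3 and compound 4 lie beyond the limit stays open, so the two methoxyphenyl placements cannot be ordered. Also open, on these data alone, is whether a dimethylamino group in place of the methoxy would return a number in this assay.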